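Methyl to Fluoro on the Benzyl Ether: Expecting Compound 4

The compounds below may be only part of what the source reports. "The series", "measured", "known", "first", "only" and "open" are said of these compounds alone.

Compound 1 `Cc1ccc(COc2ccc(C(=O)NC(=S)Nc3ccc(C)c(-c4nc5ccccc5[nH]4)c3)cc2)cc1` was tested in a functional assay on SW-620 cells (Homo sapiens) for inhibition, read by MTT assay, with a stated time of 48 h (on this read-out lower numbers stand for stronger inhibition and higher numbers for weaker inhibition), where compound 1 gives 60900 nM. Compound 2 `Cc1ccc(NC(=S)NC(=O)c2ccc(OCc3ccc(F)cc3)cc2)cc1-c1nc2ccccc2[nH]1` differs from compound 1 in a single place, (fluoro in place of methyl on an aromatic carbon), and in this assay compound 2 gives 40500 nM. The step between them, a 1.5-fold lower number from compound 1 to compound 2 (0.18 log units; within the scatter), is therefore small and sits inside the usual spread of repeated measurements.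

Compound 3 `Cc1ccc(COc2ccc(C(=O)NC(=O)Nc3ccc(Cl)c(-c4nc5ccccc5[nH]4)c3)cc2)cc1` carries a different core; how that core differs from the core of compound 1 is not broken down here. In this assay compound 3 gives 23200 nM. Against compound 2 the gap between the two values lies within the scatter, while against compound 1 it lies beyond it.

Compound 4 `O=C(NC(=O)c1ccc(OCc2ccc(F)cc2)cc1)Nc1ccc(Cl)c(-c2nc3ccccc3[nH]2)c1` has not yet been measured. It differs from compound 3 by fluoro in place of methyl on an aromatic carbon, the same change that takes compound 1 to compound 2, made at the same kind of position on the same benzyl ether. Because a 1.5-fold lower number from compound 1 to compound 2 (0.18 log units; within the scatter) stayed within the scatter, the step from compound 3 to compound 4 is expected to be modest as well, a 1.5-fold lower number from compound 3 to compound 4 (0.16 log units; within the scatter). Compound 4 is accordingly estimated to give about 16000 nM in this assay, with a plausible span from 7000 nM to 40000 nM; this rests on a single earlier instance of the change and on compound 3 as its starting point.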

Compound 4, half-maximal inhibitory concentration: 33600 nM
Compound 4: the middle estimate sits 2.1-fold (0.32 log units) below what was measured; measured number inside the range.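

In this assay, going by these compounds alone, the change from 4-methylbenzyl to 4-fluorobenzyl, carried to the second core, gives a 1.4-fold higher number from compound 3 to compound 4 (0.16 log units; within the scatter), and set beside the first instance of the change, this step does not differ from it by more than two such steps normally scatter: the same change on two cores in this assay, a 1.5-fold lower number (0.18 log units; within the scatter) from compound 1 to compound 2 and a 1.4-fold higher number (0.16 log units; within the scatter) from compound 3 to compound 4, 2.2-fold (0.34 log units) apart, within the scatter of two such steps. What this shows is that in both pairs the exchange of methyl for fluoro leaves the number within the scatter, so the opposite signs of the two steps cannot be read as a reversal that depends on the core. Within the data shown here, it does not show that the change is without effect on every core of the series, since it rests on only two pairs, at one place on the benzyl ether and in one cell assay, and it cannot say which feature of a core, if any, would alter the size of the step.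

The compounds shown leave open how a larger group such as trifluoromethyl or methoxy, or an amine or a carboxylic acid, would read at the same place on the benzyl ring in this assay. They also leave open whether fluoro placed elsewhere on that ring would give a step beyond the scatter.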